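The compounds below may be only part of what the source reports. "The series", "measured", "known", "first", "only" and "open" are said of these compounds alone.

Values in a functional assay on MOLM-13 cells (Homo sapiens) for antiproliferative activity; a lower number here means a stronger inhibitor, a higher number a weaker inhibitor:
- compound 1 `Cc1c(-c2ccc(-c3ccccc3F)cc2)nc2ccc(F)cc2c1C(=O)C(F)(F)F`: > 3000 nM (a limit of the assay, not a number)
- compound 2 `Cc1c(-c2ccc(-c3ccccc3F)cc2)nc2ccc(F)cc2c1C(N)=O`: 128 nM
- compound 3 `COC(=O)NC(=O)c1c(C)c(-c2ccc(-c3ccccc3F)cc2)nc2ccc(F)cc12`: 403 nM

Compound 3, at 403 nM, has the higher of the two actual numbers, and compound 2 is its nearest neighbour. Compound 1 gives only a limit, > 3000 nM.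

Compound 4 `Cc1c(-c2ccc(-c3ccccc3F)cc2)nc2ccc(F)cc2c1C(=O)NO` differs from compound 3 in one place: hydroxy in place of methoxycarbonyl on an amide-type nitrogen. In words, hydroxy stands in place of methoxycarbonyl on an amide-type nitrogen.

For the measured compounds named here, no measured step involves hydroxy itself, so the guidance is indirect. Putting methoxycarbonyl on the nitrogen of compound 2 gave a 3.1-fold higher number from compound 2 to compound 3 (0.50 log units; beyond the scatter), a modest loss, and compound 4 lacks that group. The two large gains, an at least 23-fold lower number from compound 1 to compound 2 (1.36 log units; beyond the scatter) and an at least 7.4-fold lower number from compound 1 to compound 3 (0.87 log units; beyond the scatter), both came with a nitrogen on the carbonyl, and compound 4 keeps one.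

A modest move to a lower number in this assay is therefore expected, back towards compound 2 at 128 nM. The estimated change is a 2.5-fold lower number from compound 3 to compound 4 (0.40 log units; beyond the scatter). Compound 4 is estimated at 160 nM, with an expected range of 40 nM to 600 nM.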

Compound 4, half-maximal inhibitory concentration: 23 nM
The estimate for compound 4 lay 7.0-fold (0.84 log units) above the measured number, outside the stated range (below it).
By their numbers in this assay, from the lowest: compound 4; then compound 2; then compound 3. At a limit, above all of these: compound 1.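

In this assay, a group on the amide-type nitrogen can improve on the amide hydrogen and not only lose to it: hydroxy in place of that hydrogen gives a 5.6-fold lower number from compound 2 to compound 4 (0.75 log units; beyond the scatter), whereas methoxycarbonyl had given a higher number. Exchanging one group for the other on this same nitrogen gives an 18-fold lower number from compound 3 to compound 4 (1.24 log units; beyond the scatter), so the choice of group here matters a great deal. Hydroxyamino in place of trifluoromethyl on the carbonyl carbon gives an at least 130-fold lower number from compound 1 to compound 4 (2.11 log units; beyond the scatter), a size that is only a lower bound, since compound 1 stands at a limit of the assay: the limit of > 3000 nM in this assay, at which 1 of the 4 values shown sits.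

The compounds shown leave open whether this gain is particular to hydroxy or would also come with methoxy or amino on the same nitrogen. They also leave open how a carboxylic acid in place of the whole carbonyl-nitrogen group would compare with compound 4.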